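The source may report more compounds than this note shows. Statements on the series, on what has been measured and on what is new or still open speak of the compounds shown alone.

In a functional assay on DU-145 cells (Homo sapiens) for inhibition, read by trypan blue exclusion, with a stated time of 96 h (a higher number here means a weaker inhibitor of growth, a lower number a stronger inhibitor of growth), compound 1 (`Cc1ccc(S(=O)(=O)/C(=C/c2ccccc2OCc2ccccc2)C(=O)c2ccc(Br)cc2)cc1`) gives 1000 nM and compound 2 (`O=C(/C(=C\c1ccccc1OCc1ccccc1)S(=O)(=O)Cc1ccc(Cl)cc1)c1ccc(Br)cc1`) gives 10000 nM as the higher of the two numbers, which makes compound 2 the weaker inhibitor of growth. Compound 3 (`O=C(/C(=C\c1ccccc1OCc1ccccc1)SCc1ccc(F)cc1)c1ccc(Br)cc1`) carries (4-fluorobenzyl)sulfanyl in place of (4-chlorobenzyl)sulfonyl on a double-bonded chain carbon bound to a carbonyl carbon and a double-bonded chain carbon. Going by the values given here, one measured step bears on this change, a modest one beyond the scatter (a 10-fold higher number from compound 1 to compound 2 (1.00 log units; beyond the scatter)) with 4-chlorobenzyl in place of 4-methylphenyl on a sulfonyl sulfur. Among the compounds with values here, no measured compound carries a sulfanyl group, so the data favour no direction, and a shift of similar size either way remains open. The expected step in this assay is no change at the digits printed from compound 2 to compound 3 (within the scatter) as a central guess. Compound 3 is estimated at 10000 nM with an expected range from 2500 nM to 40000 nM as a working figure.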

Compound 3, concentration for 50% growth inhibition: 1000 nM
For compound 3 the middle estimate is 10-fold (1.00 log units) above the measured one; the measured number lies below the stated range.
By their numbers in this assay, from the lowest: compounds 1 and 3 (each within the scatter of the next); then compound 2.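

In this assay, going by these compounds alone, the position on a double-bonded chain carbon bound to a carbonyl carbon and a double-bonded chain carbon now carries a sulfanyl group for the first time, and (4-fluorobenzyl)sulfanyl in place of (4-chlorobenzyl)sulfonyl gives a 10-fold lower number from compound 2 to compound 3 (1.00 log units; beyond the scatter) in this series. Against (4-methylphenyl)sulfonyl the same group gives no change at the digits printed from compound 1 to compound 3 (within the scatter) here, so among these three compounds a sulfonyl group at this position is not required for the lower number. No measurement at hand accounts for either step.

The step from the (4-chlorobenzyl)sulfonyl group changes the sulfur and the halogen together, so the share of each stays unresolved, and a (4-chlorobenzyl)sulfanyl group would separate them. On these data alone, how an amine or a carboxylic acid on the benzyl ring would read at this position also remains open.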